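Shrinking the benzyl substituent on a purine nucleoside core

This account rests on a few compounds, and the source may have more. Where it says the series, first, only, none or still open, it means among the compounds named here.

Measured compounds:
compound 1 `COc1ccc(Cn2c(=O)n(C3OC(CO)[C@@H](O)[C@H]3O)c3nc(N)nc(O)c32)cc1` with 44%
compound 2 `C=CCn1c(=O)n(C2C[C@H](O)C(CO)O2)c2nc(N)nc(O)c21` with 99%
compound 3 `Nc1nc(O)c2c(n1)n(C1OC(CO)[C@@H](O)[C@H]1O)c(=O)n2Cc1ccc(OCc2ccccc2)cc1` with 5%

In a functional assay on the whole organism (B cells) with Mus musculus as the target (on this read-out lower numbers stand for smaller maximal responses and higher numbers for larger maximal responses), compound 1 sits second highest of the three numbers. Compound 3 lies below it, and a number 39 percentage points lower from compound 1 to compound 3 (beyond the scatter) is a large step beyond the scatter. Compound 2 gives the highest number, but it differs from compound 1 in more than one place, so only its two values can be set side by side.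

The unmeasured compound 4 `CCn1c(=O)n(C2OC(CO)[C@@H](O)[C@H]2O)c2nc(N)nc(O)c21` arises from compound 1 by a single change: methyl in place of 4-methoxyphenyl on a saturated chain carbon bound to an aromatic nitrogen. For the measured compounds named here, this is the reverse kind of change to the one between compound 1 and compound 3, where a larger group at the same end of the molecule went with a much smaller maximal response. Going by the values given here, the one step that bears on it is therefore a number 39 percentage points lower from compound 1 to compound 3 (beyond the scatter), and the expectation runs in the opposite direction: a smaller group is expected to give a larger maximal response. Compound 4 is thus estimated at 72%, with a range from 45% to 100%. This estimate implies a step of a number 28 percentage points higher from compound 1 to compound 4 (beyond the scatter), expected to be beyond the scatter.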

Compound 4, largest response reached (reported as maximal response), in percent of the reference or control that the assay uses: 82%
Beside the measured number, compound 4's estimate is 10 percentage points below it; the measured number falls inside the stated range.
By their numbers in this assay, from the lowest: compound 3; then compound 1; then compound 4; then compound 2.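

Until now, only an enlargement at the far end of the 4-methoxybenzyl group had been seen, and it lowered the response; cutting that group back to ethyl shows that this position also moves in the other direction, with a number 38 percentage points higher from compound 1 to compound 4 (beyond the scatter) in this assay. Compound 4 carries no aromatic ring at this place and still gives 82%, so a six-membered aromatic ring here is not required for a large maximal response, and among compounds 3, 1 and 4, which share the same sugar, the number rises as the group shrinks, with no exception. Nothing shown gives a reason for this rise.
Going by these compounds, it remains open whether the ring or the overall size of the group governs the response, which a plain benzyl or a longer chain such as butyl at this place would help to separate. On these data alone, how an aminoethyl chain would behave here also stays unknown.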